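The source may hold more compounds than are shown below. What is called first, only, known or untested is meant among the compounds shown, and "the series" means these compounds.

Measured so far:
compound 1, `COc1ncc(-c2ccc3ncnc(Nc4ccc(OCCO)cc4)c3c2)cc1NS(C)(=O)=O`, 4860 nM
compound 2, `COc1ncc(-c2ccc3ncnc(Nc4cnn(CC(=O)O)c4)c3c2)cc1NS(=O)(=O)c1ccc(F)cc1F`, 1540 nM

Both compounds were tested in a functional assay on HCT-116 cells (Homo sapiens) for antiproliferative activity, read by sulforhodamine B assay, with a stated time of 72 h; a lower number here means a stronger inhibitor, a higher number a weaker inhibitor. In this assay compound 1 gives 4860 nM. Compound 2 gives 1540 nM, the lower of the two numbers, and its gap to compound 1 is beyond the usual scatter, so compound 2 is the stronger inhibitor of the pair. The two compounds differ in several places at once, so no single structural change can be tied to that gap.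

Compound 3 `COc1ncc(-c2ccc3ncnc(Nc4cnn(CCCO)c4)c3c2)cc1NS(=O)(=O)c1ccc(F)cc1F` has not yet been measured. It differs from compound 2 in one place:

2-hydroxyethyl in place of carboxy on a saturated chain carbon bound to an aromatic nitrogen

Among the compounds with values here, no measured pair shows this particular change, so there is no direct precedent to lean on. The carboxy group of compound 2 is exchanged for a 2-hydroxyethyl group of the same size, which keeps one hydrogen-bond donor and one acceptor; a large shift is not the default expectation. The step from compound 2 to compound 3 is expected to be a 1.9-fold lower number from compound 2 to compound 3 (0.28 log units; within the scatter), a modest move toward a lower number that may not clear the scatter. Compound 3 is therefore estimated at 800 nM, with a plausible range from 200 nM to 3500 nM.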

Compound 3, half-maximal inhibitory concentration: 480 nM
For compound 3 the middle estimate is 1.7-fold (0.22 log units) above the measured one, within the range that was stated.
By their numbers in this assay, from the lowest: compound 3; then compound 2; then compound 1.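

Within the data shown here, compound 2 and compound 3 are the first pair here that differ in one place, so they give the first direct reading of this position: in this assay, replacing carboxy with 2-hydroxyethyl on a saturated chain carbon bound to an aromatic nitrogen gives a 3.2-fold lower number from compound 2 to compound 3 (0.51 log units; beyond the scatter). The group at this position therefore matters in this assay, and the change makes compound 3 the stronger inhibitor of the pair. The leaving and entering groups have the same counts of heavy atoms, hydrogen-bond donors and hydrogen-bond acceptors, so those counts alone do not set the number, and no measurement shown here explains the shift.

This is a single pair, so it cannot separate the effect of removing carboxy from that of adding the hydroxyl-bearing chain, nor show whether the trend would extend to other groups. A primary amine or a methyl ether at the end of the chain, or a longer chain such as 4-hydroxybutyl, would test how specific the result in this assay is to 3-hydroxypropyl.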